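The source may hold more compounds than are shown below. What is called first, only, known or untested is meant among the compounds shown, and "the series" means these compounds.

Of the compounds shown here, three built on the same core have been measured in a functional assay on MCF7 cells (Homo sapiens) for antiproliferative activity, read by MTT assay, with a stated time of 48 h; a higher number here means a weaker inhibitor, a lower number a stronger inhibitor. Compound 1 `C=C(/C=C/c1ccc(OC)c(O)c1)c1cc(OC)c(OC)c(OC)c1` gives 569 nM in this assay, and compound 2 `C=C(/C=C/c1ccc(OC)c(N)c1)c1cc(OC)c(OC)c(OC)c1` gives 786 nM; with amino in place of hydroxy on an aromatic carbon, the step was a 1.4-fold higher number from compound 1 to compound 2 (0.14 log units; within the scatter). Compound 3 `CC=C(/C=C/c1ccc(OC)c(N)c1)c1cc(OC)c(OC)c(OC)c1` gives 247 nM, the lowest of the three numbers and beyond the scatter from both others, so compound 3 is the strongest inhibitor here. Compound 4 `CCC=C(/C=C/c1ccc(OC)c(N)c1)c1cc(OC)c(OC)c(OC)c1` is not yet measured. Its difference from compound 3: methyl in place of hydrogen on a saturated chain carbon bound to a double-bonded chain carbon The same difference, cut one bond further out, reads methyl to ethyl. For the measured compounds named here, one measured step bears on it, the one that also put a methyl in place of hydrogen on this chain, and it read a 3.2-fold lower number from compound 2 to compound 3 (0.50 log units; beyond the scatter), a modest gain. Growing the chain once more is expected to move the number only a little, if anything toward a slightly lower value. Compound 4 is therefore estimated at 200 nM, with a range of 90 nM to 450 nM, which means an expected step of a 1.2-fold lower number from compound 3 to compound 4 (0.09 log units; within the scatter), likely within the scatter.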

Compound 4, half-maximal inhibitory concentration: 486 nM
Estimate against measurement, compound 4: 2.4-fold (0.39 log units) below, outside the stated range (above it).
By their numbers in this assay, from the lowest: compounds 3, 4, 1 and 2 (each within the scatter of the next, the first and the last beyond it).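

In this assay, growing the methyl to an ethyl on this chain gives a 2.0-fold higher number from compound 3 to compound 4 (0.29 log units; within the scatter), so these two chain lengths cannot be told apart here. The ethyl also cannot be separated from the hydrogen of the parent compound, with a 1.6-fold lower number from compound 2 to compound 4 (0.21 log units; within the scatter), whereas the methyl stood clear of that hydrogen with a 3.2-fold lower number from compound 2 to compound 3 (0.50 log units; beyond the scatter), so the clear separation seen with methyl does not carry over to ethyl. Nothing measured here explains this behaviour of the chain.

From the compounds shown here alone, whether a propyl group, a longer chain or a branched isopropyl group at this place would stay in the same range remains open. Also open, going by these compounds, is whether a methyl or ethyl here would read the same with the hydroxy of compound 1 in place of the amino group.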